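Nitro to amino in the trimethoxybenzyl series

A few compounds are considered here, and "the series" means these few. Any claim that something is new, unique, unknown or untested is made for them only; others in the source may bear on it.

Measured in a functional assay on K562 cells (Homo sapiens) for cytotoxicity, read by MTT assay, with a stated time of 5 days; a lower number here means a stronger inhibitor, a higher number a weaker inhibitor:
- compound 1 `COc1ccc(-c2cnnn2Cc2cc(OC)c(OC)c(OC)c2)cc1` gives 5560 nM
- compound 2 `COc1ccc(-c2cnnn2Cc2cc(OC)c(OC)c(OC)c2)cc1[N+](=O)[O-]` gives > 10000 nM (a limit)

In this assay compound 2 gives > 10000 nM, which is a limit of the assay and not a number. The next compound is compound 3 `COc1ccc(-c2cnnn2Cc2cc(OC)c(OC)c(OC)c2)cc1N`, and the change is amino in place of nitro on an aromatic carbon, ortho to a methoxy group.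

Going by the values given here, only one measured step bears on this change, an at least 1.7-fold higher number from compound 1 to compound 2 (0.25 log units; that floor lies within the scatter), nitro in place of hydrogen. Among the compounds with values here, it gives a floor and no true size, and no measured compound carries an amino group. The working anchor is therefore compound 1 at 5560 nM, which has hydrogen at the same carbon. Going by these compounds, removing the nitro group is expected to bring the number down towards that anchor, though the amino group itself remains untested and the range must stay wide.

For compound 3 the expected value is 3000 nM, with an estimated range of 500 nM to 10000 nM. The estimate amounts to an expected at least 3.3-fold lower number from compound 2 to compound 3 (0.52 log units; beyond the scatter).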

Compound 3, half-maximal inhibitory concentration: 380 nM
Compound 3: the middle estimate sits 7.9-fold (0.90 log units) above what was measured, outside the stated range (below it).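

In this assay, the carbon ortho to a methoxy group is now shown to allow a gain over hydrogen, with amino in place of hydrogen giving a 15-fold lower number from compound 1 to compound 3 (1.17 log units; beyond the scatter). Compound 2 alone showed only a nitro group that could not be told apart from hydrogen beyond the scatter, whereas amino in place of nitro on the same carbon gives an at least 26-fold lower number from compound 2 to compound 3 (1.42 log units; beyond the scatter), so the outcome here depends on which group is present and not on substitution as such. The value of compound 2 is a limit and not a number, which makes that step a floor with no true size: the limit of > 10000 nM in this assay, at which 1 of the 3 values shown sits.

The compounds shown leave open whether the gain is particular to the amino group or extends to a hydroxyl, a methylamino or an acetamido group on the same carbon. They also leave open how the amino group would fare if the methoxy group it sits ortho to gave way to an ethoxy or a hydroxyl group.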